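Swapping a furan for a pyridine on a ketone-bearing core

This account rests on a few compounds, and the source may have more. Where it says the series, first, only, none or still open, it means among the compounds named here.

Two compounds share a long unsaturated chain ending in a ketone attached to a small aromatic core. Compound 1 `CCCCCCCC/C=C\CCCCCCC(=O)c1ncc(-c2ccco2)o1` carries a furan-2-yl group on that core; compound 2 `CCCCCCCC/C=C\CCCCCCC(=O)c1nc2cccnc2o1` has the core fused to a second ring. In an assay on isolated protein for inhibition of Fatty-acid amide hydrolase 1 (Homo sapiens) (a higher number here means a weaker inhibitor, a lower number a stronger inhibitor), compound 1 gives 54 nM, the higher of the two numbers, while compound 2 gives 11 nM, a gap that lies beyond the usual scatter. Compound 3 `CCCCCCCC/C=C\CCCCCCC(=O)c1ncc(-c2ccncc2)o1` has not yet been measured. It differs from compound 1 by one change: pyridin-4-yl in place of furan-2-yl on an aromatic carbon. Among the compounds with values here, no measured pair shows this exact swap, so the direction is uncertain; the replacement of one small aromatic ring by another of similar size is expected to move the number modestly, if at all, with a slight lean toward a stronger inhibitor. Compound 3 is therefore estimated at 25 nM, within 6 nM to 100 nM, a step of a 2.2-fold lower number from compound 1 to compound 3 (0.33 log units; beyond the scatter).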

Compound 3, inhibition constant: 56 nM
Compound 3: middle estimate off by 2.2-fold (0.35 log units), on the low side; low and high end bracket the measured number.
By their numbers in this assay, from the lowest: compound 2; then compounds 1 and 3 (each within the scatter of the next).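

In this assay, pyridin-4-yl in place of furan-2-yl gives a 1.0-fold higher number from compound 1 to compound 3 (0.02 log units; within the scatter), so the two compounds cannot be told apart. At this aromatic carbon, next to the ring oxygen, a six-membered aromatic ring with one nitrogen therefore reads the same as a five-membered aromatic ring with one oxygen, even with one more heavy atom. No independent measurement is available to say why the two rings read alike.

The compounds shown leave open whether the same holds for pyridin-3-yl or pyridin-2-yl, where the ring nitrogen sits elsewhere, or for a plain phenyl ring with no ring nitrogen at all. They also leave open how this position would respond to a group of a different kind, such as an amine or a carboxylic acid.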